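The source may hold more compounds than are shown below. What is called first, only, known or untested is meant among the compounds shown, and "the series" means these compounds.

Measured so far in a functional assay on KB cells (Homo sapiens) for inhibition; a higher number here means a weaker inhibitor of growth, a lower number a stronger inhibitor of growth:
Compound 1, `O=C(COc1ccc(/C=C2\SC(=O)NC2=O)cc1)Nc1ccc(Cl)cc1`: 50300 nM
Compound 2, `O=C(COc1ccc(/C=C2\SC(=O)NC2=O)cc1)Nc1c(F)cc(Br)cc1F`: > 100000 nM, a limit of the assay rather than a number.

Compound 1 carries the only number shown; the remaining value is a limit. Compound 2 sits at the limit of > 100000 nM in this assay, at which 1 of the 2 values shown sits. The step of an at least 1.9-fold higher number from compound 1 to compound 2 (0.29 log units; that floor lies within the scatter) therefore gives only a floor. Compound 3 `O=C(COc1ccc(/C=C2\SC(=O)NC2=O)cc1)Nc1ccc(Cl)cc1C(F)(F)F` differs from compound 1 by trifluoromethyl in place of hydrogen on an aromatic carbon, another change on the same ring, so the measured step bears on it only loosely. No gain is expected; the step of a 1.4-fold higher number from compound 1 to compound 3 (0.14 log units; within the scatter) is expected to be a higher number or none beyond the scatter. For compound 3 the estimate is 70000 nM, between 25000 nM and 200000 nM.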

Compound 3, concentration for 50% growth inhibition: > 100000 nM
Compound 3 was reported as a limit; the forecaster's own chance of this, stated with the estimate: 35%; middle value at least 1.4-fold (0.15 log units) away from the limit.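

In this assay, trifluoromethyl in place of hydrogen, ortho to a large group and meta to a chloro group, gives an at least 1.9-fold higher number from compound 1 to compound 3 (0.29 log units; that floor lies within the scatter). Compound 3 stands at a limit rather than a number, so this position yields only a floor and no measured size of change. Both changed compounds shown now end at the limit rather than at a number: the limit of > 100000 nM in this assay, at which 2 of the 3 values shown sit.

On these data alone, whether a methyl group, an amine or a carboxylic acid at this position would give a number remains open. As far as these compounds go, the true distance between compound 1 and compound 3 also remains open.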